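The source may hold more compounds than are shown below. What is called first, only, known or untested is meant among the compounds shown, and "the series" means these compounds.

Of the compounds shown here, three built on one shared core have been tested in an assay on Prostate gland for inhibition of steroid 5-alpha-reductase (Rattus norvegicus); a higher number here means a weaker inhibitor, a lower number a stronger inhibitor. Compound 1 `CCCn1ccc2cc(/C(C)=C/C(=O)Nc3ccccc3OCCCC(=O)O)ccc21` gives 190 nM, compound 2 `CCCCCCn1ccc2cc(/C(C)=C/C(=O)Nc3ccccc3OCCCC(=O)O)ccc21` gives 77 nM, and compound 3 `C/C(=C\C(=O)Nc1ccccc1OCCCC(=O)O)c1ccc2c(ccn2Cc2ccc(C(F)(F)F)cc2)c1` gives 300 nM. Compound 3 thus holds the highest number of the three: its gap to compound 1 lies within the scatter, while a 3.9-fold higher number from compound 2 to compound 3 (0.59 log units; beyond the scatter). Compound 4 `C/C(=C\C(=O)Nc1ccccc1OCCCC(=O)O)c1ccc2c(ccn2C(C)c2ccccc2)c1` differs from compound 3 by 1-phenylethyl in place of 4-(trifluoromethyl)benzyl on an aromatic nitrogen. Going by the values given here, the measured steps touching this position are a 1.6-fold higher number from compound 1 to compound 3 (0.20 log units; within the scatter) and a 3.9-fold higher number from compound 2 to compound 3 (0.59 log units; beyond the scatter); both exchange a chain for an aryl group, not one aryl group for another, so no direct precedent exists. The expected step is a 1.2-fold lower number from compound 3 to compound 4 (0.08 log units; within the scatter). Compound 4 is therefore estimated in this assay at 250 nM, within a range from 100 nM to 650 nM.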

Compound 4, half-maximal inhibitory concentration: 19 nM
The estimate for compound 4 lay 13-fold (1.12 log units) above the measured number; measured number below the stated range.
By their numbers in this assay, from the lowest: compound 4; then compound 2; then compounds 1 and 3 (each within the scatter of the next).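

Placing 1-phenylethyl on the aromatic nitrogen gives a 16-fold lower number from compound 3 to compound 4 (1.20 log units; beyond the scatter) in this assay, so exchanging one aryl-bearing group for another can matter far more here than the earlier chain-to-aryl steps showed. It also outperforms both straight chains, with a 4.1-fold lower number from compound 2 to compound 4 (0.61 log units; beyond the scatter) and a 10-fold lower number from compound 1 to compound 4 (1.00 log units; beyond the scatter), making compound 4 the strongest inhibitor of the four. Nothing available explains this gain.

This single step both removes the trifluoromethyl group and adds the methyl of 1-phenylethyl, and the compounds shown cannot separate the two changes. A plain benzyl group on the same nitrogen would tell them apart.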